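The compounds below may be only part of what the source reports. "The series", "measured", "known", "first", "only" and "open" are said of these compounds alone.

Measured in a functional assay on MCF7 cells (Homo sapiens) for antiproliferative activity, read by MTT assay, with a stated time of 72 h; a lower number here means a stronger inhibitor, a higher number a weaker inhibitor:
- compound 1 `C=C(Br)C(=O)Nc1ccc2c(c1)/C(=C\c1sccc1C)C(=O)N2` gives 2300 nM
- compound 2 `C=C(Br)C(=O)Nc1ccc2c(c1)/C(=C/c1ccsc1)C(=O)N2` gives 2800 nM

Compound 2 lies within the scatter of compound 1, so these two values cannot be ordered. Among the measured compounds shown here, no step between measured compounds that differ in one place is available, which leaves the next change without a direct precedent.

Compound 3 `C=C(Br)C(=O)Nc1ccc2c(c1)/C(=C/c1sccc1C)C(=O)N2` differs from compound 2 as follows: 3-methylthiophen-2-yl in place of thiophen-3-yl on a double-bonded chain carbon bound to a double-bonded ring carbon on a double-bonded chain carbon bound to a double-bonded ring carbon. Compound 1 also carries 3-methylthiophen-2-yl and gives 2300 nM in the same test, so no change beyond the scatter is expected in this assay and neither direction is favoured. The expected change is a 1.2-fold lower number from compound 2 to compound 3 (0.09 log units; within the scatter) in this estimate. For compound 3 the estimated value is 2300 nM with an expected range of 800 nM to 6500 nM for repeat measurements.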

Compound 3, half-maximal inhibitory concentration: 2600 nM
Estimate against measurement, compound 3: 1.1-fold (0.05 log units) below; low and high end bracket the measured number.
By their numbers in this assay, from the lowest: compounds 1, 3 and 2 (each within the scatter of the next).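

In this assay, 3-methylthiophen-2-yl in place of thiophen-3-yl on a double-bonded chain carbon bound to a double-bonded ring carbon gives a 1.1-fold lower number from compound 2 to compound 3 (0.03 log units; within the scatter), so this exchange of one thiophene group for another leaves no readable change. Among the compounds shown here, the double-bond configuration can now be compared directly for the first time, with a 1.1-fold higher number from compound 1 to compound 3 (0.05 log units; within the scatter), and the E and Z forms as drawn are not separated in this test. Reading that step as a comparison of configuration alone rests on one point: the fact that compounds 1 and 3 differ only in the configuration as drawn

Going by these compounds, whether activity at this position responds to anything other than a thiophene stays open, for example a phenyl ring carrying an amine or a carboxylic acid. Also open, on these data alone, is whether the E and Z forms remain inseparable with a different group at this place.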